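The source may report more compounds than this note shows. Statements on the series, on what has been measured and on what is new or still open speak of the compounds shown alone.

Compound 1 `Cc1ccccc1-c1nn(-c2ccc(F)cc2F)cc1CN1CCN(c2ccccc2)CC1`: in an ADME assay on Huh-7 cells (Homo sapiens) for cytotoxicity (on this read-out lower numbers stand for higher toxicity in this test and higher numbers for lower toxicity in this test), compound 1 gives > 20000 nM, which is a limit of the assay rather than a number.
Compound 2 `CN1CCN(CCNCc2cn(-c3ccc(F)cc3F)nc2-c2ccccc2)CC1`: compound 2 gives > 20000 nM, again a limit.
Compound 3 `Cc1ccccc1-c1nn(-c2ccc(Br)cc2)cc1CNCCN1CCN(C)CC1`: compound 3 gives 9600 nM.

Compound 2 therefore has no numerical value in this assay; it sits at the limit of > 20000 nM in this assay, at which 2 of the 3 values shown sit, so all that can be said is that its half-maximal cytotoxic concentration lies at the limit, with compound 3 the only one of the three to give a number. Going by the values given here, no pair among the measured compounds differs in just one place, so no measured step is available to lean on. Compound 4 `CN1CCN(CCNCc2cn(-c3ccc(F)cc3F)nc2-c2ccc(Cl)cc2)CC1` differs from compound 2 by chloro in place of hydrogen on an aromatic carbon, the phenyl becoming 4-chlorophenyl. With nothing in the set to point the other way, the change in this assay is expected to be none beyond the scatter, and another reading at the limit is the most likely outcome; the expected step is a number no higher from compound 2 to compound 4 (the limit leaves the size open). Compound 4 is thus estimated at 20000 nM, within 8000 nM to 50000 nM.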

Compound 4, half-maximal cytotoxic concentration: 19000 nM
The estimate for compound 4 lay 1.1-fold (0.02 log units) above the measured number; the measured number falls inside the stated range.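

Placing chloro on an aromatic carbon, para to a large group, turns phenyl into 4-chlorophenyl and gives the first step on this position in this assay: an at least 1.0-fold lower number from compound 2 to compound 4 (0.02 log units; that floor lies within the scatter). Compound 4 returns a number where compound 2 does not, yet the floor of that step lies within the scatter, so the change shows no clear rise in toxicity in this test. As far as these compounds go, the true size of the step stays open because the value of compound 2 is a limit: the limit of > 20000 nM in this assay, at which 2 of the 4 values shown sit.

The compounds shown leave open how far compound 2 lies past its limit, and so whether the chloro has any real effect on the read-out. They also leave open how a fluoro, a methoxy or an amine at this same place would read.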